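Formyl gives way to 2-acetylethenyl in compound 2

The source may report more compounds than this note shows. Statements on the series, on what has been measured and on what is new or still open speak of the compounds shown alone.

Compound 1 `C=C[C@@](C)(/C=C/c1ccc(O)c(/C=C/c2ccc(F)cc2)c1)CCC=C(C)C` gives > 36600 nM as a limit
Compound 2 `COc1ccc(/C=C/[C@@](C)(/C=C/c2ccc(O)c(C=O)c2)CCC=C(C)C)cc1` gives 4550 nM as a number

Both results come from a functional assay on SEM cells (Homo sapiens) for cytotoxicity, with a stated time of 72 h (a higher number here means that more compound is needed for the effect, a lower number that less compound is needed), and are all that is known so far. For the measured compounds named here, compound 2 at 4550 nM holds the only true number, so it is the sole anchor for what follows.

Compound 3 `COc1ccc(/C=C/[C@@](C)(/C=C/c2ccc(O)c(/C=C/C(C)=O)c2)CCC=C(C)C)cc1` has not yet been measured. It carries 2-acetylethenyl in place of formyl on an aromatic carbon, ortho to a hydroxy group 2-acetylethenyl in place of formyl on an aromatic carbon and meta to a large group. Going by the values given here, no measured pair differs in one place, so this change has no direct precedent here. In this assay a modest move towards a lower number is expected, only slightly beyond the usual scatter. The estimate means an expected step of a 1.6-fold lower number from compound 2 to compound 3 (0.21 log units; within the scatter) in this assay. Compound 3 is estimated at 2800 nM with an expected range from 800 nM to 10000 nM.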

Compound 3, half-maximal effective concentration: 8670 nM
Estimate against measurement, compound 3: 3.1-fold (0.49 log units) below; measured number inside the range.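

For the compounds shown here, compound 2 and compound 3 give the first comparison at this position, on an aromatic carbon ortho to a hydroxy group and meta to a large group. In this assay, putting 2-acetylethenyl in place of formyl gives a 1.9-fold higher number from compound 2 to compound 3 (0.28 log units; within the scatter), so a group of five heavy atoms with two double bonds is accepted here as readily as one of two heavy atoms with one, within what repeated measurements can resolve. Both groups hold a carbonyl, and the data shown give no cause for the size of this step.

On these data alone, what an amine or a carboxylic acid would do on this same carbon stays open. So does whether the double bond of 2-acetylethenyl matters, which the saturated 3-oxobutyl chain could test.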